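Spiro series: aryl-triazole variation against HepG2 proliferation

The source may report more compounds than this note shows. Statements on the series, on what has been measured and on what is new or still open speak of the compounds shown alone.

Compound 3 `COc1ccccc1-n1nncc1CN1C(=O)C2(C(C#N)=C(N)Oc3c2c2nc4ccccc4nc2c2ccccc32)c2ccccc21` is the reference point. In a functional assay on HepG2 cells (Homo sapiens) for antiproliferative activity, read by MTT assay, with a stated time of 48 h (on this read-out lower numbers stand for stronger inhibition and higher numbers for weaker inhibition), compound 3 reaches only the assay limit, > 50000 nM. Compound 1 `N#CC1=C(N)Oc2c(c3nc4ccccc4nc3c3ccccc23)C12C(=O)N(Cc1cnnn1-c1ccc(F)cc1)c1ccccc12` likewise stops at a limit in this assay, > 50000 nM. Compound 2 `N#CC1=C(N)Oc2c(c3nc4ccccc4nc3c3ccccc23)C12C(=O)N(Cc1cnnn1-c1ccc(Br)cc1)c1ccccc12` also returns a limit in this assay, > 50000 nM. All three values rest on (the limit of > 50000 nM in this assay, at which 3 of the 3 values shown sit), so every pairwise step is unreadable: a step that the two limits leave unreadable from compound 1 to compound 2, a step that the two limits leave unreadable from compound 1 to compound 3 and a step that the two limits leave unreadable from compound 2 to compound 3.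

Compound 4 `N#CC1=C(N)Oc2c(c3nc4ccccc4nc3c3ccccc23)C12C(=O)N(Cc1cnnn1-c1ccc(S(N)(=O)=O)cc1)c1ccccc12` differs from compound 3 by 4-sulfamoylphenyl in place of 2-methoxyphenyl on an aromatic nitrogen. For the measured compounds named here, the measured steps that bear on an exchange of the aryl group on this nitrogen are a step that the two limits leave unreadable from compound 1 to compound 3 and a step that the two limits leave unreadable from compound 2 to compound 3, and neither gives a readable size, while no measured step involves a sulfamoyl group at all. With three limits and no readable step, the expectation in this assay is a further limit rather than a number, with only a modest chance of a measurable value emerging. Compound 4 is therefore expected at 60000 nM, with a range from 15000 nM to 250000 nM. The expected step is a step that the limit leaves unreadable from compound 3 to compound 4, nothing beyond the scatter.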

Compound 4, half-maximal inhibitory concentration: 42200 nM
Compound 4: middle estimate off by 1.4-fold (0.15 log units), on the high side, and the stated range covers the measured number.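

In this assay, for the compounds shown here, compound 4 gives 42200 nM, the only number so far, so a change on this aromatic nitrogen can yield a readable value. Even so, the change can be sized only as a floor against each of the other compounds: an at least 1.1-fold lower number from compound 3 to compound 4 (0.07 log units; that floor lies within the scatter), an at least 1.1-fold lower number from compound 2 to compound 4 (0.07 log units; that floor lies within the scatter) and an at least 1.1-fold lower number from compound 1 to compound 4 (0.07 log units; that floor lies within the scatter). The 4-sulfamoylphenyl group therefore gives a readable value but no established gain over 2-methoxyphenyl, and the other comparisons still rest on a single limit: the limit of > 50000 nM in this assay, at which 3 of the 4 values shown sit.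

The compounds shown leave open how far the true values of compound 1, compound 2 and compound 3 lie from that of compound 4. They also leave open whether an amine or a carboxylic acid in place of the sulfamoyl group would give a number, and of what size.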